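Cytotoxicity notes on the aminobenzyl series, first step outward

The source may hold more compounds than are shown below. What is called first, only, known or untested is meant among the compounds shown, and "the series" means these compounds.

Two compounds of the series have been run in a toxicity assay on NIH3T3 cells (Mus musculus) for cytotoxicity, read by resazurin assay; on this read-out higher numbers stand for an effect only at larger amounts of compound and lower numbers for an effect already at smaller amounts. Compound 1 `COC(=O)c1ccc(NCc2cncn2Cc2ccc(N)cc2)cc1-c1ccccc1` gives only a limit: in this assay compound 1 reads > 10000 nM, a limit of the assay and not a number. Compound 2 `Nc1cc(-c2ccccc2)ccc1Cn1cncc1CNc1ccc(-c2cncs2)c(-c2ccccc2)c1` likewise gives only a limit, reading > 1000 nM in this assay. The two readings therefore sit at the limit of > 10000 nM in this assay, at which 1 of the 2 values shown sits, and at the limit of > 1000 nM in this assay, at which 1 of the 2 values shown sits, and compound 1 cannot be placed on a scale of numbers; it is only known to show no effect within the tested range. Among the measured compounds shown here, no step between measured compounds exists in this assay.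

Compound 3 `COC(=O)c1ccc(NCc2cncn2Cc2cccc(Cl)c2)cc1-c1ccccc1` has not yet been measured. It differs from compound 1 by 3-chlorophenyl in place of 4-aminophenyl on a saturated chain carbon bound to an aromatic nitrogen. With compound 1 at a limit, no measured direction can be anchored for this change. Compound 3 is expected to show a step that the limit leaves unreadable from compound 1 to compound 3, which is no larger than the usual scatter, and the reading is expected to remain a limit more often than not. Compound 3 is estimated at 12000 nM in this assay, with a range from 3000 nM to 50000 nM.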

Compound 3, half-maximal effective concentration: > 10000 nM
Compound 3 gave a limit, no number; the forecaster's own chance of this, stated with the estimate: 70%; the middle value is on the limit's open side.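

In this assay, among the compounds shown here, compound 1 and compound 3 both stand at a limit of the assay and not at a number, and no step between them can be read. The compounds shown leave open where either would fall on a scale of numbers, and whether 3-chlorophenyl in place of 4-aminophenyl shifts the read-out at all.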